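A few compounds are considered here, and "the series" means these few. Any claim that something is new, unique, unknown or untested is made for them only; others in the source may bear on it.

Measured compounds:
Compound 1 `O=C(Nc1ccc(OC(F)(F)F)cc1)NC1CCN(C(=O)c2ccoc2)CC1`: 7.6 ug/mL
Compound 2 `O=C(Nc1ccc(OC(F)(F)F)cc1)NC1CCN(C(=O)[C@@H]2CCOC2)CC1`: 23 ug/mL
Compound 3 `Cc1ccoc1C(=O)N1CCC(NC(=O)Nc2ccc(C(F)(F)F)cc2)CC1`: 0.8 ug/mL

All three were measured in a physicochemical assay for solubility, read by mass spectrometry, in phosphate buffer, with a stated time of 24 h, at pH 7.4; on this read-out lower numbers stand for lower solubility and higher numbers for higher solubility. Compound 3 gives the lowest of the three numbers; compound 1 is the nearest to it and compound 2 the furthest, and both gaps lie beyond the scatter. Among the measured compounds shown here, compound 1 and compound 2 carry a trifluoromethoxy group where compound 3 carries trifluoromethyl, and no single step joins compound 3 to either of them, so their values show only that compound 3 sits well under both in this assay.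

Compound 4 `O=C(Nc1ccc(C(F)(F)F)cc1)NC1CCN(C(=O)C2CCOC2)CC1` has not yet been measured in this assay. It differs from compound 3 in one place: oxolan-3-yl in place of 3-methylfuran-2-yl on a carbonyl carbon. For the measured compounds named here, the one measured step that bears on this change is a 3.0-fold higher number from compound 1 to compound 2 (0.48 log units; beyond the scatter). That step does not cover the 3-methylfuran-2-yl group of compound 3, which is not the same ring as furan-3-yl, so it is only a partial guide. On this basis compound 4 is expected to give a higher number than compound 3, a 3.8-fold higher number from compound 3 to compound 4 (0.57 log units; beyond the scatter), a step of modest size in the direction of greater solubility. The estimate for compound 4 in this assay is 3 ug/mL, with a range from 1 ug/mL to 10 ug/mL.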

Compound 4, solubility: 9.6 ug/mL
Compound 4: middle estimate off by 3.2-fold (0.51 log units), on the low side; the measured number falls inside the stated range.
By their numbers in this assay, from the lowest: compound 3; then compounds 1 and 4 (each within the scatter of the next); then compound 2.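

In this assay, the change from 3-methylfuran-2-yl to oxolan-3-yl on a carbonyl carbon gives a 12-fold higher number from compound 3 to compound 4 (1.08 log units; beyond the scatter), a large step that extends the earlier reading of this position to the trifluoromethyl series and to a ring bearing a methyl group. Alongside a 3.0-fold higher number from compound 1 to compound 2 (0.48 log units; beyond the scatter), a modest step, it gives two pairs in which oxolan-3-yl goes with the higher number than the aromatic ring it replaces, and neither compound pair shown goes against this, although the two pairs differ in both the ring that leaves and the group on the far side of the urea. Nothing shown gives a measured property that would account for the size of the new step.

The compounds shown leave open how much of the larger step belongs to the methyl group of 3-methylfuran-2-yl and how much to the change of ring, a question that furan-2-yl on the same carbonyl carbon would bear on. They also leave open how an open chain ether or an amine would read at this position, and whether trifluoromethyl and trifluoromethoxy differ when all else is held the same.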